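The source may report more compounds than this note shows. Statements on the series, on what has been measured and on what is new or still open speak of the compounds shown alone.

Working notes on the series. The open-chain carbamate compound 1 `CCCCCCCCC#CC(=O)[C@H](CO)NC(=O)OC(C)(C)C` and its cyclic relative compound 2 `CCCCCCCCC#CC(=O)[C@@H]1COC(C)(C)N1C(=O)OC(C)(C)C` have both been run in an assay on CHO cells for inhibition of sphingosine kinase 1 (Homo sapiens), tested at 10 uM; a lower number here means less inhibition, a higher number more inhibition at the concentration tested (going by the name of the read-out). Compound 1 gives 4.2%, the lower of the two numbers; compound 2 gives 15.2%, a gap beyond the scatter. The two differ in more than one place, so the gap is reported as it stands. Compound 3 `CCCCCCCCCCCCCC#CC(=O)[C@H](CO)NC(=O)OC(C)(C)C` awaits measurement. It carries pentyl in place of hydrogen on a saturated chain carbon, eight bonds along the chain from a triple-bonded carbon. For this change the expected step is small and upward, roughly at the edge of the scatter: a number 5.8 percentage points higher from compound 1 to compound 3 (within the scatter). Compound 3 is thus estimated at 10%, within 0% to 30%.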

Compound 3, a percentage reported as inhibition, at one concentration (the size of the read-out at that concentration, not a potency): 56.9%
Beside the measured number, compound 3's estimate is 46.9 percentage points below it; measured number above the stated range.
By their numbers in this assay, from the lowest: compound 1; then compound 2; then compound 3.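

Going by these compounds alone, in the first single-place comparison, pentyl in place of hydrogen on a saturated chain carbon, eight bonds along the chain from a triple-bonded carbon, gives in this assay a number 52.7 percentage points higher from compound 1 to compound 3 (beyond the scatter). This position on the chain therefore has a large bearing on the read-out at the concentration tested. Nothing at hand accounts for the size of the step.

Still open, as far as these compounds go, is how a longer chain than that of compound 3, or an amine on the chain, would read. Also open, from the compounds shown here alone, is whether the same extension carries over to the cyclic relative, compound 2.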